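Swapping morpholin-4-yl for anilino in compound 3

The source may hold more compounds than are shown below. What is called first, only, known or untested is meant among the compounds shown, and "the series" means these compounds.

In a functional assay on MCF7 cells (Homo sapiens) for antiproliferative activity, read by MTT assay, with a stated time of 24 h (a higher number here means a weaker inhibitor, a lower number a stronger inhibitor), compound 1 `CCCCc1oc2ccccc2c1C(=O)c1ccc(OCC(=O)NC(C)C)cc1` gives > 50000 nM, which is a limit and not a number. Compound 2 `CCCCNC(=O)COc1ccc(C(=O)c2c(CCCC)oc3ccccc23)cc1` also gives only a limit, > 50000 nM. Compound 3 `CCCCc1oc2ccccc2c1C(=O)c1ccc(OCC(=O)N2CCOCC2)cc1` is the only one of the three with a real number, 34000 nM.

Compound 4 `CCCCc1oc2ccccc2c1C(=O)c1ccc(OCC(=O)Nc2ccccc2)cc1` differs from compound 3 in one place anilino in place of morpholin-4-yl on a carbonyl carbon. For the measured compounds named here, compound 4 thereby regains the amide hydrogen found in compound 1 and compound 2, although no measured compound carries anilino.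

Going by the values given here, two measured steps bear on this change, read in reverse: an at least 1.4-fold lower number from compound 1 to compound 3 (0.16 log units; that floor lies within the scatter) and an at least 1.4-fold lower number from compound 2 to compound 3 (0.16 log units; that floor lies within the scatter). Both are floors only, so they point weakly towards a higher number for compound 4 and give no firm size. A small rise in this assay, not clearly beyond the scatter, is therefore expected. The expected change is a 1.3-fold higher number from compound 3 to compound 4 (0.12 log units; within the scatter). For compound 4 the estimated value is 45000 nM, with an expected range from 18000 nM to 90000 nM.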

Compound 4, half-maximal inhibitory concentration: 33600 nM
Compound 4: the middle estimate sits 1.3-fold (0.13 log units) above what was measured, and the stated range covers the measured number.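

In this assay, a 1.0-fold lower number from compound 3 to compound 4 (0.01 log units; within the scatter) shows that anilino and morpholin-4-yl on this carbonyl carbon cannot be told apart, even though anilino brings back the amide hydrogen; an amide hydrogen therefore does not always go with a limit, as it does in compound 1 and compound 2. Against those two compounds, the change of the group on the amide-type nitrogen to phenyl gives an at least 1.4-fold lower number from compound 2 to compound 4 (0.17 log units; that floor lies within the scatter) and an at least 1.4-fold lower number from compound 1 to compound 4 (0.17 log units; that floor lies within the scatter). The true size of these two steps stays unread because each starts from a limit, which is not a number: the limit of > 50000 nM in this assay, at which 2 of the 4 values shown sit.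

The compounds shown leave open whether any group on this carbonyl carbon, such as benzylamino or a piperazine ring, moves the number beyond the scatter. They also leave open what a carboxylic acid in place of the amide would do.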